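Removing the acetyl group from compound 3

The source may hold more compounds than are shown below. What is called first, only, known or untested is meant among the compounds shown, and "the series" means these compounds.

Compound 3 (`CC(=O)OCCNC1CCCc2onc(O)c21`) gives > 500000 nM in a functional assay with Mus musculus as the target; a lower number here means a stronger inhibitor, a higher number a weaker inhibitor. That value is a limit of the assay and not a number.

Compound 4 (`OCCNC1CCCc2onc(O)c21`) differs from it by hydrogen in place of acetyl on an oxygen on a saturated carbon, so acetoxy becomes hydroxy. Going by the values given here, two measured steps bear on this change. Compound 1 (`NC1CCCc2onc(O)c21`) gives 208000 nM and compound 2 (`CCNC1CCCc2onc(O)c21`) gives 278000 nM, and ethyl on the amine nitrogen accounts for a 1.3-fold higher number from compound 1 to compound 2 (0.13 log units; within the scatter). Acetoxy on the chain then accounts for an at least 1.7-fold higher number from compound 2 to compound 3 (0.25 log units; that floor lies within the scatter). Among the compounds with values here, no step measured in this small set lies beyond the scatter, and none removes an acetyl group.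

A modest move towards a lower number is therefore expected in this assay, though its size cannot be fixed from a limit. The estimate means an expected at least 1.6-fold lower number from compound 3 to compound 4 (0.22 log units; that floor lies within the scatter). Compound 4 is expected at 300000 nM, with an estimated range of 130000 nM to 700000 nM.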

Compound 4, half-maximal inhibitory concentration: > 500000 nM
Compound 4 gave a limit, no number (the forecaster's own chance of this, stated with the estimate: 30%); at least 1.6-fold (0.22 log units) between middle value and limit.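

In this assay compound 4 gives > 500000 nM, a limit of the assay and not a number. Hydrogen in place of acetyl therefore does not bring the number under the limit, and the step between compound 3 and compound 4 cannot be read, because both stand at the same limit: the limit of > 500000 nM in this assay, at which 2 of the 4 values shown sit. 2-Hydroxyethyl on the amine nitrogen gives an at least 2.4-fold higher number from compound 1 to compound 4 (0.38 log units; beyond the scatter), a step beyond the scatter, which the earlier steps were not, whereas hydroxy on the chain gives an at least 1.7-fold higher number from compound 2 to compound 4 (0.25 log units; that floor lies within the scatter).

On these data alone, how far compound 3 and compound 4 lie past the limit stays open. Also open, as far as these compounds go, is whether an amine or a carboxylic acid in place of hydroxy, or a longer chain, would return a readable number.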